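The source may report more compounds than this note shows. Statements on the series, on what has been measured and on what is new or still open speak of the compounds shown alone.

The shared core of this set changes at only one aromatic carbon, and the two measured compounds both stop at the edge of what the assay can report. Compound 1 `FC(F)(F)c1nc2c(Br)cccc2c(Cl)c1Br` has a bromine at that carbon. In an assay for inhibition of ectonucleoside triphosphate diphosphohydrolase 8 (Homo sapiens), read by malachite green, with a stated time of 10 min (on this read-out higher numbers stand for weaker inhibition and lower numbers for stronger inhibition), compound 1 gives > 300000 nM, which is a limit of the assay rather than a number. Compound 2 `N#Cc1cccc(-c2cccc3c(Cl)c(Br)c(C(F)(F)F)nc23)c1` carries a 3-cyanophenyl group in place of that bromine. In this assay compound 2 gives > 300000 nM, again a limit and not a number. That step, a step that the two limits leave unreadable from compound 1 to compound 2, therefore cannot be read in size or direction; what is known is only (the limit of > 300000 nM in this assay, at which 2 of the 2 values shown sit). Compound 3 `FC(F)(F)c1nc2c(-c3ccsc3)cccc2c(Cl)c1Br` is the next compound, and its change is thiophen-3-yl in place of 3-cyanophenyl on an aromatic carbon. Going by the values given here, the single step that bears on it is unreadable, so no size of step in this assay can be expected beyond the scatter, and the likeliest outcome is that compound 3 also sits at the limit. Compound 3 is estimated at 300000 nM, within a range from 100000 nM to 1000000 nM, an expected step of a number no higher from compound 2 to compound 3 (the limit leaves the size open).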

Compound 3, half-maximal inhibitory concentration: > 300000 nM
Compound 3: only a limit was reported (the forecaster's own chance of this, stated with the estimate: 80%); the middle value sits exactly at the limit.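

In this assay compound 3 gives > 300000 nM, again a limit and not a number. Going by these compounds alone, this means that no step among compound 1, compound 2 and compound 3 can be read in size or direction: the limit of > 300000 nM in this assay, at which 3 of the 3 values shown sit. The compounds shown leave open whether any group at this aromatic carbon would give a value the assay can report as a number.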